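A few compounds are considered here, and "the series" means these few. Any claim that something is new, unique, unknown or untested is made for them only; others in the source may bear on it.

Compound 1 `Clc1cc(Cl)cc(CO[C@H]2CCCN(Cc3ccc(-c4nn[nH]n4)cc3)[C@H]2c2ccccc2)c1` and compound 2 `CN1CCC[C@H](O[C@H](CO)c2cc(Cl)cc(Cl)c2)[C@@H]1c1ccccc1` share the core. In an assay on isolated protein for activation of cGMP-dependent protein kinase 1 (Homo sapiens), read by ADP-Glo, with stated times of 120 min and 40 min (a higher number here means that more compound is needed for the effect, a lower number that less compound is needed), compound 1 gives 74000 nM, and in this assay compound 2 gives 42000 nM. Compound 2 has the lowest of the two numbers, though its gap to compound 1 lies within the scatter of repeat measurements. Compound 3 `OC[C@@H](O[C@H]1CCCN(Cc2ccc(-c3nn[nH]n3)cc2)[C@H]1c1ccccc1)c1cc(Cl)cc(Cl)c1` is reached from compound 2 by 4-(2H-tetrazol-5-yl)phenyl in place of hydrogen on a saturated chain carbon bound to an amine nitrogen in a ring. Within the data shown here, compound 1 already carries the same 4-(2H-tetrazol-5-yl)benzyl group, but no measured step isolates this change on the hydroxymethyl series. The step from compound 2 to compound 3 is expected to be a 1.1-fold lower number from compound 2 to compound 3 (0.02 log units; within the scatter), nothing beyond the scatter. Compound 3 is estimated at 40000 nM, in a range from 15000 nM to 120000 nM.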

Compound 3, half-maximal effective concentration: 131000 nM
Compound 3: middle estimate off by 3.3-fold (0.52 log units), on the low side; measured number outside the range, above it.
By their numbers in this assay, from the lowest: compounds 2, 1 and 3 (each within the scatter of the next, the first and the last beyond it).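

In this assay, methyl to 4-(2H-tetrazol-5-yl)benzyl gives a 3.1-fold higher number from compound 2 to compound 3 (0.49 log units; beyond the scatter), so at this place on the hydroxymethyl series the change carries a modest cost in the amount of compound needed. Hydroxymethyl in place of hydrogen on the other side of the molecule gives a 1.8-fold higher number from compound 1 to compound 3 (0.25 log units; within the scatter), so with 4-(2H-tetrazol-5-yl)benzyl present, that change stays within the scatter. Nothing available accounts for the rise with 4-(2H-tetrazol-5-yl)benzyl. Open, from the compounds shown here alone, is whether plain benzyl, or a carboxylic acid in place of the tetrazole ring, would give the same number.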